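The source may hold more compounds than are shown below. What is called first, only, known or untested is meant among the compounds shown, and "the series" means these compounds.

Measured so far in an in vitro assay on HEK385-7 cells for displacement of a labelled ligand from prostaglandin D2 receptor 2 (Homo sapiens); on this read-out higher numbers stand for weaker inhibition and lower numbers for stronger inhibition:
compound 1 `O=C(O)Cc1sc(C(c2ccc(F)cc2)c2ccc(F)cc2)nc1-c1ccnc(N2CCCC2)c1` gives 230 nM;
compound 3 `COc1ccc(C(c2ccccc2)c2nc(-c3ccc(Cl)cc3)c(CC(=O)O)s2)cc1` gives 8.4 nM;
compound 2 `COc1ccc(OC)c(-c2nc(C(c3ccccc3)c3ccccc3)sc2CC(=O)O)c1` gives only the limit > 105 nM.

Compound 1 holds the higher of the two numbers. Compound 3 sits at a lower number, a gap beyond the scatter. For compound 2 the value is a limit of this assay, not a number (the limit of > 105 nM in this assay, at which 1 of the 3 values shown sits).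

Compound 4 `Cc1cc(-c2nc(C(c3ccc(F)cc3)c3ccc(F)cc3)sc2CC(=O)O)ccn1` is not yet measured. It differs from compound 1 in one place (methyl in place of pyrrolidin-1-yl on an aromatic carbon).

For the measured compounds named here, the single change removes most of the group at that position. A step toward a higher number in this assay is expected from compound 1 to compound 4, of moderate size, about a 2.0-fold higher number from compound 1 to compound 4 (0.29 log units; within the scatter), though it may fall within the scatter. Compound 4 is estimated at 450 nM, with a range from 130 nM to 1600 nM.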

Compound 4, half-maximal inhibitory concentration: 3.1 nM
Estimate against measurement, compound 4: 150-fold (2.16 log units) above, outside the stated range (below it).
By their numbers in this assay, from the lowest: compound 4; then compound 3; then compound 1.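

In this assay, the change from 2-(pyrrolidin-1-yl)pyridin-4-yl to 2-methylpyridin-4-yl gives a 74-fold lower number from compound 1 to compound 4 (1.87 log units; beyond the scatter), so the group at this position, next to the ring nitrogen, has a large bearing on the read-out. With the rest of the structure unchanged, the pyrrolidin-1-yl ring is not needed here, and methyl serves far better. Nothing measured in this series accounts for the size of this step.

From the compounds shown here alone, whether the ring itself or simply the larger group costs the activity stays open, as only these two groups are compared at this position. A hydrogen, an ethyl, a methoxy or a dimethylamino group there would separate these readings.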